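From 4-methoxyphenyl to 4-iodophenyl: working notes

A few compounds are considered here, and "the series" means these few. Any claim that something is new, unique, unknown or untested is made for them only; others in the source may bear on it.

Compound 1 `COc1cccc(-c2cc([N+](=O)[O-])cc3cc(C(O)(c4ccc(C#N)cc4)c4cncn4C)oc23)c1`: 38.8 nM
Compound 2 `COc1ccc(C(O)(c2cc3cc([N+](=O)[O-])cc(-c4ccccc4)c3o2)c2cncn2C)cc1`: 4970 nM

In a functional assay on QG-56 cells (Homo sapiens) for antiproliferative activity (a higher number here means a weaker inhibitor, a lower number a stronger inhibitor), compound 2, at 4970 nM, has the higher number of the two, well beyond the scatter from compound 1. Compound 3 `Cn1cncc1C(O)(c1ccc(I)cc1)c1cc2cc([N+](=O)[O-])cc(-c3ccccc3)c2o1` carries iodo in place of methoxy on an aromatic carbon, para to a large group (iodo in place of methoxy on an aromatic carbon). Among the compounds with values here, no measured pair isolates this change. Within the data shown here, the only guide is compound 1 at 38.8 nM, which also lacks the 4-methoxyphenyl group, though it differs elsewhere too. The expected change in this assay is a moderate fall in the number, a 3.3-fold lower number from compound 2 to compound 3 (0.52 log units; beyond the scatter). For compound 3 the estimated value is 1500 nM, with an expected range of 300 nM to 6000 nM.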

Compound 3, half-maximal inhibitory concentration: > 10000 nM
Compound 3 ended at the assay's limit (the forecaster's own chance of this, stated with the estimate: 3%); middle value at least 6.6-fold (0.82 log units) away from the limit.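

In this assay compound 3 gives a limit of the assay and not a number: the limit of > 10000 nM in this assay, at which 1 of the 3 values shown sits.

Within the data shown here, this is the first pair that differs in one place, and iodo in place of methoxy on the aromatic carbon gives an at least 2.0-fold higher number from compound 2 to compound 3 (0.30 log units; that floor lies within the scatter). No fall in the number appears with this change, and the true size of the step cannot be read from a limit.

Compound 1 differs from both compounds in more than one place, so it does not settle this position. As far as these compounds go, what an amine or a carboxylic acid would give on this aromatic carbon remains open.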